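The source may hold more compounds than are shown below. What is called first, only, known or untested is meant among the compounds shown, and "the series" means these compounds.

In a functional assay on V79 cells (Cricetulus griseus) for cytotoxicity, read by colony formation (a higher number here means a weaker inhibitor, a lower number a stronger inhibitor), three compounds sharing one core have been measured. Compound 3 `NC1CCN(c2c(F)cc3c(=O)c(C(=O)O)cn(C4CC4)c3c2Cl)CC1` gives 18 ug/mL and compound 1 `CNCC1(C)CCN(c2c(F)cc3c(=O)c(C(=O)O)cn(C4CC4)c3c2Cl)C1` gives 23 ug/mL, and these two cannot be told apart, as a 1.3-fold lower number from compound 1 to compound 3 (0.11 log units; within the scatter) shows. Compound 2 `CC1CN(c2c(F)cc3c(=O)c(C(=O)O)cn(C4CC4)c3c2Cl)CC(C)N1` gives 140 ug/mL, and it stands clearly apart from both, with a 6.1-fold higher number from compound 1 to compound 2 (0.78 log units; beyond the scatter) on one side and a 7.8-fold lower number from compound 2 to compound 3 (0.89 log units; beyond the scatter) on the other.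

Compound 4 `CC1CN(c2c(F)cc3c(=O)c(C(=O)O)cn(C4CC4)c3c2Cl)CCN1` has not yet been measured. It departs from compound 3 by one change on an aromatic carbon, ortho to a chloro group and ortho to a fluoro group: 3-methylpiperazin-1-yl in place of 4-aminopiperidin-1-yl on an aromatic carbon. The entering 3-methylpiperazin-1-yl most closely resembles the 3,5-dimethylpiperazin-1-yl of compound 2, so the measured step that bears most directly is a 7.8-fold lower number from compound 2 to compound 3 (0.89 log units; beyond the scatter), which is modest but beyond the scatter. Read in reverse, it points towards a higher number. Among the compounds with values here, no measured pair isolates the second methyl group of compound 2, so the full size of that step need not carry over. The expected step is therefore somewhat smaller, at a 3.9-fold higher number from compound 3 to compound 4 (0.59 log units; beyond the scatter). For compound 4 the estimated value is 70 ug/mL, with an expected range from 25 ug/mL to 180 ug/mL.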

Compound 4, half-maximal inhibitory concentration: 45 ug/mL
For compound 4 the middle estimate is 1.6-fold (0.19 log units) above the measured one; measured number inside the range.
By their numbers in this assay, from the lowest: compounds 3, 1 and 4 (each within the scatter of the next, the first and the last beyond it); then compound 2.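

In this assay, the step from compound 2 to compound 4 isolates one methyl group on a saturated ring carbon: a 3.1-fold lower number from compound 2 to compound 4 (0.49 log units; beyond the scatter). The methyl group therefore accounts for part of the gap that the earlier compounds showed only as an exchange of whole substituents on this aromatic carbon, ortho to a chloro group and ortho to a fluoro group. Rearranging the same atoms also registers here, with 3-methylpiperazin-1-yl in place of 4-aminopiperidin-1-yl giving a 2.5-fold higher number from compound 3 to compound 4 (0.40 log units; beyond the scatter), whereas the exchange for 3-methyl-3-((methylamino)methyl)pyrrolidin-1-yl gives a 2.0-fold higher number from compound 1 to compound 4 (0.29 log units; within the scatter) and does not separate those two compounds. No experimental evidence is available to explain these steps.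

The compounds shown leave open how the number would stand with a plain piperazin-1-yl carrying no methyl group, or with an ethyl group in place of the methyl of 3-methylpiperazin-1-yl. They also leave open whether the methyl step would keep its size if a hydrogen stood in place of the chloro group.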